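The source may hold more compounds than are shown below. What is called first, only, known or untested is meant among the compounds shown, and "the series" means these compounds.

Series notes. Compound 1 `COc1cccc([C@@H](CO)O[C@H]2CCCN(Cc3ccc(C(=O)O)cc3C)[C@H]2c2ccccc2)c1` is the starting point, and in an assay on isolated protein for activation of cGMP-dependent protein kinase 1 (Homo sapiens), read by ADP-Glo, with stated times of 30 min and 2 h (a higher number here means that more compound is needed for the effect, a lower number that less compound is needed), compound 1 gives only a limit, > 200000 nM. Compound 2 `Cc1cc(C(=O)O)ccc1CN1CCC[C@H](O[C@H](CO)c2ccccc2)[C@@H]1c1ccccc1` likewise gives only a limit in this assay, > 200000 nM. Compound 3 `Cc1cc(C(=O)O)ccc1CN1CCC[C@H](O[C@H](CO)c2cc(Cl)nc(Cl)c2)[C@@H]1c1ccccc1` also returns only a limit in this assay, > 200000 nM. Within the data shown here, because every value so far sits at the limit of > 200000 nM in this assay, at which 3 of the 3 values shown sit, the steps a step that the two limits leave unreadable from compound 1 to compound 2, a step that the two limits leave unreadable from compound 1 to compound 3 and a step that the two limits leave unreadable from compound 2 to compound 3 cannot be sized. Compound 4 `Cc1cc(C(=O)O)ccc1CN1CCC[C@H](OC(c2cc(Cl)cc(Cl)c2)C(C)O)[C@@H]1c1ccccc1` differs from compound 3 by a group of 12 heavy atoms (9 carbon, 1 oxygen, 2 chlorine; one six-membered aromatic ring of carbon only) in place of a group of 11 heavy atoms (7 carbon, 1 nitrogen, 1 oxygen, 2 chlorine; one six-membered aromatic ring with 1 hetero atom), on an oxygen on a saturated carbon. Those three unreadable steps are the only ones bearing on this change and give no direction, so a further limit is expected for compound 4 in this assay, with the step of a number no higher from compound 3 to compound 4 (the limit leaves the size open) expected to be flat. Compound 4 is estimated at 200000 nM, between 100000 nM and 400000 nM.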

Compound 4, half-maximal effective concentration: > 196000 nM
Compound 4 was reported as a limit; the forecaster's own chance of this, stated with the estimate: 85%; the middle value lies beyond the limit too.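

In this assay compound 4 gives > 196000 nM as a limit, and its steps from compound 1, compound 2 and compound 3 cannot be read. The compounds shown leave open which group on the oxygen on a saturated carbon, if any, would give a measurable value in this assay at all.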